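This account rests on a few compounds, and the source may have more. Where it says the series, first, only, none or still open, it means among the compounds named here.

The shared core appears in compound 1 `C#CCSc1nc(NCCC(C)C)c2ccncc2n1`. In a functional assay on PC-3 cells (Homo sapiens) for inhibition, read by MTT assay, with a stated time of 72 h (on this read-out higher numbers stand for weaker inhibition and lower numbers for stronger inhibition), compound 1 gives > 80000 nM, which is a limit of the assay and not a number. Compound 2 `C#CCSc1nc(NCCC#N)c2ccncc2n1` is its one-place neighbour. In this assay compound 2 gives > 80000 nM, again a limit of the assay and not a number. Going by the values given here, only one step is measured, a step that the two limits leave unreadable from compound 1 to compound 2, and its size cannot be read, since both of its ends sit at the limit of > 80000 nM in this assay, at which 2 of the 2 values shown sit. Compound 2 thus stands at the limit, and no order between it and compound 1 can be stated.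

Compound 3 `C#CCSc1nc(Nc2ccccc2)c2ccncc2n1` differs from compound 2 by phenyl in place of 2-cyanoethyl on a nitrogen on an aromatic ring. The single measured step exchanges one chain for another and is unreadable; no measured step puts a ring on this nitrogen, so nothing in the numbers shown points to a direction or a size for the change. The expected step of a number no higher from compound 2 to compound 3 (the limit leaves the size open) is therefore set at no change beyond the scatter, with compound 3 most likely reaching only the limit once more. Compound 3 is estimated at 80000 nM, with a range from 20000 nM to 200000 nM.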

Compound 3, half-maximal inhibitory concentration: > 80000 nM
Compound 3: only a limit was reported; the forecaster's own chance of this, stated with the estimate: 70%; the middle value sits exactly at the limit.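

In this assay compound 3 gives > 80000 nM, which is a limit of the assay and not a number. The steps joining compound 3 to compound 1 and compound 2 cannot be read, since all their ends sit at the same limit: the limit of > 80000 nM in this assay, at which 3 of the 3 values shown sit.

The compounds shown leave open how strongly any of them inhibits, and whether the group on this nitrogen changes that.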